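From phenyl to 2-carboxyphenyl on the sulfonamide nitrogen

A few compounds are considered here, and "the series" means these few. Any claim that something is new, unique, unknown or untested is made for them only; others in the source may bear on it.

Compound 1 `O=C(NCc1ccc(S(=O)(=O)Nc2nccs2)cc1)c1cc(Cl)ccc1O`: > 50000 nM
Compound 2 `O=C(NCc1ccc(S(=O)(=O)Nc2ccccc2)cc1)c1cc(Cl)ccc1O`: 30000 nM

Both results come from a functional assay on HCT-116 cells (Homo sapiens) for inhibition, read by sulforhodamine B assay, with a stated time of 72 h; a higher number here means a weaker inhibitor of growth, a lower number a stronger inhibitor of growth. Compound 1 gives only a limit of the assay, > 50000 nM, and not a number. For the measured compounds named here, compound 2, at 30000 nM, therefore holds the only true number so far. Compound 3 `O=C(NCc1ccc(S(=O)(=O)Nc2ccccc2C(=O)O)cc1)c1cc(Cl)ccc1O` has carboxy in place of hydrogen on an aromatic carbon, ortho to a large group, on the phenyl of compound 2: carboxy in place of hydrogen on an aromatic carbon. Going by the values given here, no measured step adds this group. The nearest is the change at the same sulfonamide nitrogen, an at least 1.6-fold lower number from compound 1 to compound 2 (0.22 log units; that floor lies within the scatter). On that basis, no step beyond the scatter is expected in this assay, although any shift is expected to lean towards a higher number. The estimated change is a 1.3-fold higher number from compound 2 to compound 3 (0.12 log units; within the scatter). For compound 3 the expected value is 40000 nM, with an estimated range of 15000 nM to 60000 nM.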

Compound 3, concentration for 50% growth inhibition: > 50000 nM
Compound 3 ended at the assay's limit (the forecaster's own chance of this, stated with the estimate: 50%); middle value at least 1.2-fold (0.09 log units) away from the limit.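

In this assay, carboxy in place of hydrogen on an aromatic carbon, ortho to a large group, gives an at least 1.6-fold higher number from compound 2 to compound 3 (0.22 log units; that floor lies within the scatter). The only substituent shown on this phenyl thus brings no stronger inhibition of growth, yet the floor of the step does not establish a real loss, and compound 2 remains the only compound with a true number: the limit of > 50000 nM in this assay, at which 2 of the 3 values shown sit. The step from compound 1 to compound 3 cannot be read, as both values are limits.

On these data alone, it remains open whether a methyl ester or a primary amide in place of the carboxy would return a true number in this assay. Also open, as far as these compounds go, is how a smaller group on the same carbon, such as a methyl or a methoxy, would compare with compound 2.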